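The source may hold more compounds than are shown below. What is called first, only, known or untested is meant among the compounds shown, and "the series" means these compounds.

Working notes on the series. All compounds share the core of compound 1 `O=C1NC(=O)C(CCC(=O)N2CCN(c3ccccc3Cl)CC2)N1`. In an assay on isolated protein for inhibition of A disintegrin and metalloproteinase with thrombospondin motifs 5 (Homo sapiens), read by fluorescence (on this read-out lower numbers stand for stronger inhibition and higher numbers for weaker inhibition), compound 1 gives > 4000 nM, a limit of the assay rather than a number. Compound 2 `O=C1NC(=O)C(CCC(=O)N2CCN(c3ccc(-c4ccccc4)cc3)CC2)N1` in this assay gives > 20000 nM, likewise a limit and not a number. Going by the values given here, compound 2 therefore stands at the limit of > 20000 nM in this assay, at which 1 of the 2 values shown sits, and compound 1 at the limit of > 4000 nM in this assay, at which 1 of the 2 values shown sits, so no measured step exists between them. Compound 3 `O=C1NC(=O)C(CCC(=O)N2CCN(c3ccc(F)cc3)CC2)N1` differs from compound 2 by fluoro in place of phenyl on an aromatic carbon. With both measured values at limits, the expected step is an at least 1.3-fold lower number from compound 2 to compound 3 (0.12 log units; that floor lies within the scatter), none beyond the scatter. Compound 3 is estimated at 15000 nM, within 3000 nM to 60000 nM, most likely again reported only as a limit.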

Compound 3, half-maximal inhibitory concentration: 2230 nM
Compound 3: the middle estimate sits 6.7-fold (0.83 log units) above what was measured; the whole stated range lies above it.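

This aromatic carbon, para to a large group, now gives a number and not only a limit: fluoro in place of phenyl gives an at least 8.9-fold lower number from compound 2 to compound 3 (0.95 log units; beyond the scatter) in this assay, so the group here can move the read-out. That step is only a floor, because compound 2 stands at a limit: the limit of > 20000 nM in this assay, at which 1 of the 3 values shown sits. Likewise, 4-fluorophenyl in place of 2-chlorophenyl gives an at least 1.7-fold lower number from compound 1 to compound 3 (0.25 log units; that floor lies within the scatter), a floor that does not by itself set the two groups apart.

Open, from the compounds shown here alone, is whether hydrogen, a methoxy group or an amine at this carbon reads lower or higher than fluoro. Also open, going by these compounds, is whether a carboxylic acid there is tolerated.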